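Working notes: three compounds at the limit, one analogue pending

A few compounds are considered here, and "the series" means these few. Any claim that something is new, unique, unknown or untested is made for them only; others in the source may bear on it.

Measured so far in a functional assay on RAW264.7 cells (Mus musculus) for inhibition, read by Griess assay, with stated times of 1 h and 24 h; a lower number here means a stronger inhibitor, a higher number a weaker inhibitor:
compound 1 `O=C1OC(Cc2nc(Cc3ccccc3)no2)c2ccccc21`: > 10000 nM
compound 2 `O=C1OC(Cc2nc(-c3ccc(Oc4ccccc4)cc3)no2)c2ccccc21`: > 10000 nM
compound 3 `COCCOc1ccc(C(O)C2OC(=O)c3c(OC)cc(OC)cc32)cc1`: > 10000 nM

In this assay compound 1 gives > 10000 nM, which is a limit of the assay and not a number. Compound 2 gives > 10000 nM in this assay, likewise a limit. Compound 3 gives > 10000 nM in this assay, again a limit. Compound 3 therefore stands nowhere in particular on the numbers shown: it sits at the limit of > 10000 nM in this assay, at which 3 of the 3 values shown sit, together with the other two, and no value separates any of the three from the others. Going by the values given here, no step between measured compounds is available, so the series itself gives no measured direction for the next change.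

Compound 4 `COc1cc(OC)c2c(c1)C(C(O)c1ccc(OCc3ccc(OC(F)F)cc3)cc1)OC2=O` is still to be measured in this assay. It differs from compound 3 as follows: 4-(difluoromethoxy)phenyl in place of methoxymethyl on a saturated chain carbon bound to an oxygen on an aromatic ring. Among the compounds with values here, with no measured step to lean on, the expectation for the step from compound 3 to compound 4 is a modest one, an at least 1.2-fold lower number from compound 3 to compound 4 (0.09 log units; that floor lies within the scatter), toward a stronger inhibitor, though the chance that compound 4 also returns only a limit remains real. The estimate for compound 4 in this assay is 8000 nM, with a range of 1500 nM to 30000 nM.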

Compound 4, half-maximal inhibitory concentration: 5030 nM
The estimate for compound 4 lay 1.6-fold (0.20 log units) above the measured number, within the range that was stated.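

Compound 3 gives > 10000 nM in this assay, which is a limit of the assay and not a number. Going by these compounds alone, exchanging methoxymethyl for 4-(difluoromethoxy)phenyl on a saturated chain carbon bound to an oxygen on an aromatic ring gives the only step available, an at least 1.9-fold lower number from compound 3 to compound 4 (0.29 log units; that floor lies within the scatter); the printed floor does not by itself establish a difference beyond the scatter, but it shows that this position can carry the larger, ring-bearing group while a number is still obtained. Compound 4 is the only compound shown that gives a number rather than a limit: the limit of > 10000 nM in this assay, at which 3 of the 4 values shown sit.

The size of the step remains open on its upper side, and the compounds shown do not separate the contribution of the added aromatic ring from that of the difluoromethoxy group, as the two enter together. Also open, from the compounds shown here alone, is how this position would respond to a plain phenyl ring without fluorine, an amine or a carboxylic acid, and a single step gives no trend for the series.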